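Quinoxaline Sulfones: Predicting a Trifluoromethyl Swap

The source may hold more compounds than are shown below. What is called first, only, known or untested is meant among the compounds shown, and "the series" means these compounds.

Four compounds share one core and are compared in a functional assay on KB cells (Homo sapiens) for cytotoxicity, read by MTT assay, with a stated time of 72 h; on this read-out lower numbers stand for stronger inhibition and higher numbers for weaker inhibition. Compound 1 `COc1ccc(S(=O)(=O)c2nc3ccccc3nc2Nc2ccc(Cl)cc2)cc1` gives 49800 nM in this assay. Compound 2 `COc1ccc(S(=O)(=O)c2nc3ccccc3nc2Nc2ccc(C(F)(F)F)cc2)cc1` differs from compound 1 by trifluoromethyl in place of chloro on an aromatic carbon, and in this assay compound 2 gives 890 nM; the change gave a 56-fold lower number from compound 1 to compound 2 (1.75 log units; beyond the scatter). Compound 3 `O=S(=O)(c1ccc(Br)cc1)c1nc2ccccc2nc1Nc1ccc(Cl)cc1` differs from compound 1 by bromo in place of methoxy on an aromatic carbon, and in this assay compound 3 gives 11600 nM, a step of a 4.3-fold lower number from compound 1 to compound 3 (0.63 log units; beyond the scatter). Compound 2 and compound 3 differ in two places, and their two values show compound 2 with the lower number.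

Compound 4 `O=S(=O)(c1ccc(Br)cc1)c1nc2ccccc2nc1Nc1ccc(C(F)(F)F)cc1` has not yet been measured in this assay. It differs from compound 3 by trifluoromethyl in place of chloro on an aromatic carbon, the same change that separates compound 1 from compound 2, made once before among these compounds. Among the compounds with values here, because compound 1 to compound 2 gave a 56-fold lower number from compound 1 to compound 2 (1.75 log units; beyond the scatter), the step from compound 3 to compound 4 is expected to be of similar size, estimated as a 39-fold lower number from compound 3 to compound 4 (1.59 log units; beyond the scatter), with only one earlier example to rest on. Compound 4 is therefore expected to reach about 300 nM, estimated between 80 nM and 1500 nM.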

Compound 4, half-maximal inhibitory concentration: > 50000 nM
Compound 4: a limit, no number (the forecaster's own chance of this, stated with the estimate: 2%); middle value at least 160-fold (2.22 log units) from the limit.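

Compound 4 gives > 50000 nM in this assay, which is a limit of the assay and not a number. Trifluoromethyl in place of chloro gave an at least 4.3-fold higher number from compound 3 to compound 4 (0.63 log units; beyond the scatter), the reverse of its direction on the core of compound 1, so the change did not carry from one core to the other, though this single pair gives neither a rule for other cores nor the full size of the step: the same change on two cores in this assay, a 56-fold lower number (1.75 log units; beyond the scatter) from compound 1 to compound 2 and an at least 4.3-fold higher number (0.63 log units; beyond the scatter) from compound 3 to compound 4, at least 240-fold (2.38 log units) apart, beyond the scatter of two such steps Bromo in place of methoxy turned around in the same way, giving an at least 56-fold higher number from compound 2 to compound 4 (1.74 log units; beyond the scatter): the same change on two cores in this assay, a 4.3-fold lower number (0.63 log units; beyond the scatter) from compound 1 to compound 3 and an at least 56-fold higher number (1.74 log units; beyond the scatter) from compound 2 to compound 4, at least 240-fold (2.38 log units) apart, beyond the scatter of two such steps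

The compounds shown leave open whether this reversal belongs only to the pairing of trifluoromethyl with bromo or also appears with other groups. They also leave open how a nitrile or a methyl group in place of trifluoromethyl would behave alongside bromo, and what a measured number for compound 4 would be in a range that reaches it.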